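Cyclopropyl to methyl: working notes on compound 4

A few compounds are considered here, and "the series" means these few. Any claim that something is new, unique, unknown or untested is made for them only; others in the source may bear on it.

Three measured compounds carry the cyclopropyl group: compound 1 `O=C(NC1CCCc2ccccc21)c1cnn2c(C(F)F)cc(C3CC3)nc12`, compound 2 `O=C(NC1CCOc2ccccc21)c1cnn2c(C(F)F)cc(C3CC3)nc12` and compound 3 `CC1(C)CC(NC(=O)c2cnn3c(C(F)F)cc(C4CC4)nc23)c2ccccc2O1`. Within the data shown here, in a functional assay on A-375 cells (Homo sapiens) for antiproliferative activity, read by trypan blue exclusion and crystal violet staining, with a stated time of 72 h (a lower number here means a stronger inhibitor, a higher number a weaker inhibitor), compound 3 gives 2200 nM, the lower of the only two numbers available. Compound 1 gives 5000 nM, and this gap to compound 3 lies beyond the scatter. Compound 2 is reported as "not active" (no number reported), without a number.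

The next compound to read is compound 4 `Cc1cc(C(F)F)n2ncc(C(=O)NC3CC(C)(C)Oc4ccccc43)c2n1`, which departs from compound 3 in one place: methyl in place of cyclopropyl on an aromatic carbon. The group that changes sits next to the ring nitrogen and meta to a difluoromethyl group.

Among the measured compounds shown here, no measured pair isolates this change, so the series gives no direct size for it. A moderate move towards a weaker inhibitor in this assay is expected, slightly beyond the scatter, though a result within the scatter would not be surprising. Since compound 2 is reported as "not active" (no number reported), compound 4 may also end without a number. The expected change is a 2.3-fold higher number from compound 3 to compound 4 (0.36 log units; beyond the scatter). For compound 4 the estimated value is 5000 nM, with an expected range from 2000 nM to 15000 nM.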

Compound 4, half-maximal inhibitory concentration: "not active" (no number reported)
The entry for compound 4 holds no number; the estimate stays without a comparison.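

Among these compounds, compound 4 is reported as "not active" in this assay, with no number, so no step from compound 3 can be read, although compound 3 gives 2200 nM. The compounds shown leave open how far methyl in place of cyclopropyl shifts the number. Nothing measured here offers an explanation for this result.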